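The source may hold more compounds than are shown below. What is called first, only, known or untested is meant among the compounds shown, and "the series" means these compounds.

Among the compounds with values here, compound 2, with the structure `Cc1ccc(C)c(C(=O)OC(CCN(C)C)c2ccc(Cl)cc2)c1`, is measured in an assay on NIH3T3 cells with Urotensin-2 receptor (Homo sapiens) as the target (on this read-out lower numbers stand for an effect already at smaller amounts and higher numbers for an effect only at larger amounts of compound), where compound 2 gives 1860 nM, the higher of the two numbers known so far. Its nearest neighbour is compound 1, with the structure `CCc1ccccc1C(=O)OC(CCN(C)C)c1ccc(Cl)cc1`, which in this assay gives 1290 nM; the step of a 1.4-fold higher number from compound 1 to compound 2 (0.16 log units; within the scatter) is within the scatter. Compound 3, with the structure `Cc1ccc(C(=O)OC(CCN(C)C)c2ccc(Cl)cc2)cc1`, has not yet been measured. It differs from compound 2 in one place: 4-methylphenyl in place of 2,5-dimethylphenyl on a carbonyl carbon. Within the data shown here, the only measured step that bears on this change is a 1.4-fold higher number from compound 1 to compound 2 (0.16 log units; within the scatter), which also exchanged one aromatic ring for another on a carbonyl carbon and stayed within the scatter. From that single step, no shift beyond the scatter is expected in either direction. Compound 3 is therefore estimated at 1500 nM, within a range from 600 nM to 4000 nM, an expected step of a 1.2-fold lower number from compound 2 to compound 3 (0.09 log units; within the scatter).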

Compound 3, half-maximal effective concentration: 2750 nM
For compound 3 the middle estimate is 1.8-fold (0.26 log units) below the measured one; the measured number falls inside the stated range.
By their numbers in this assay, from the lowest: compounds 1, 2 and 3 (each within the scatter of the next, the first and the last beyond it).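

Exchanging the 2,5-dimethylphenyl for 4-methylphenyl on the carbonyl carbon gives a 1.5-fold higher number from compound 2 to compound 3 (0.17 log units; within the scatter) in this assay, so a second change of this aromatic group also stays within the scatter. Going from 2-ethylphenyl to 4-methylphenyl gives a 2.1-fold higher number from compound 1 to compound 3 (0.33 log units; beyond the scatter), the first step at this place that passes the scatter, though only modestly. Nothing available here explains this shift.

The three groups shown differ only in their methyl or ethyl substituents on a carbon-only aromatic ring, so these compounds cover a narrow range of change at this place. As far as these compounds go, how a plain phenyl, or a ring bearing a methoxy group, an amine or a carboxylic acid, would read in this assay remains open.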